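Permeability notes: the chain change from compound 3 to compound 4

The compounds below may be only part of what the source reports. "The series", "measured", "known", "first", "only" and "open" are said of these compounds alone.

Measured in an ADME assay on Caco-2 cells (Homo sapiens) for permeability, read by LC-MS, in the apical to basolateral direction, with a stated time of 60 min, at pH 6.5; a lower number here means that the compound crosses the layer more slowly, a higher number that the compound crosses the layer faster:
- compound 1 `O=C(NCc1cc(Cl)ccc1-n1cnnn1)[C@@H]1C[C@@H]2C[C@@H]2N1C(=O)[C@H](O)Cc1ccccn1` gives 1.2 10^-6 cm/s
- compound 2 `CC(C)(C)[C@@H](O)C(=O)N1Cc2ccccc2[C@H]1C(=O)NCc1cc(Cl)ccc1-n1nnnn1` gives 9 10^-6 cm/s
- compound 3 `CC1(C[C@@H](O)C(=O)N2C[C@H]3C[C@H]3[C@H]2C(=O)NCc2cc(Cl)ccc2-n2cnnn2)CC1` gives 2.2 10^-6 cm/s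

Compound 3 and compound 1 lie within the scatter of each other, so no order between them is read. Compound 2 stands apart from compound 3 by a gap beyond the scatter, its number being the higher one of that pair. Compound 2 also differs from the others in its core, so that gap is not assigned to any single change.

Compound 4 `CCCC[C@@H](O)C(=O)N1C[C@H]2C[C@H]2[C@H]1C(=O)NCc1cc(Cl)ccc1-n1cnnn1` is not yet measured. Its difference from compound 3 is propyl in place of 1-methylcyclopropyl on a saturated chain carbon, two bonds along the chain from a carbonyl carbon and an oxygen on a saturated carbon. Both groups are saturated carbon, with no donors or acceptors entering or leaving, and nothing else in the molecule moves. For the measured compounds named here, no measured pair in this set isolates such a change, so the expectation rests on the small size of the change alone. A step within the scatter is expected, with no clear direction, and compound 4 is estimated at 2.2 10^-6 cm/s, between 1.1 10^-6 cm/s and 4.4 10^-6 cm/s. The step from compound 3 expected is no change at the digits printed from compound 3 to compound 4 (within the scatter).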

Compound 4, apparent permeability: 33 10^-6 cm/s
Compound 4: the middle estimate sits 15-fold (1.18 log units) below what was measured, and the stated range ends below it.
By their numbers in this assay, from the lowest: compounds 1 and 3 (each within the scatter of the next); then compound 2; then compound 4.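

In this assay, this position on the chain turns out to be far from silent: propyl in place of 1-methylcyclopropyl gives a 15-fold higher number from compound 3 to compound 4 (1.18 log units; beyond the scatter), although both groups are saturated carbon and neither carries a hydrogen-bond donor or acceptor. For the compounds shown here, the earlier compounds offered no pair differing in one place, so this is the first single change read, and it shows that a swap between two plain carbon groups at this place can produce a large step. Nothing measured on these compounds accounts for that step.

The ring and the heavy-atom count change together here, so the compounds shown do not separate the removal of the three-membered ring from the removal of one carbon. Also open, going by these compounds, is how a longer chain such as pentyl, or a propyl chain ending in an amine, would read at this place.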